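Methyl ester to free acid on the shared core

The compounds below may be only part of what the source reports. "The series", "measured", "known", "first", "only" and "open" are said of these compounds alone.

Measured so far:
- compound 1 `COC(=O)c1ccc2ccc(C(=O)c3ccccc3)c-2cc1` gives 28.9% in an assay on cells for displacement of a labelled ligand from Orexin receptor type 2 (Homo sapiens), read by scintillation counting, with stated times of 10 min and 90 min, tested at 10 uM; on this read-out higher numbers stand for more inhibition at the one concentration tested (going by the name of the read-out) and lower numbers for less inhibition
- compound 2 `COC(=O)c1ccc2ccc(C(=O)c3ccc(C(F)(F)F)cc3)c-2cc1` gives -47.4% in this assay

Compound 1 stands highest of the two numbers in this assay; the nearest is compound 2, a number 76.3 percentage points lower from compound 1 to compound 2 (beyond the scatter). That step is trifluoromethyl in place of hydrogen on an aromatic carbon.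

Compound 3 `O=C(O)c1ccc2ccc(C(=O)c3ccccc3)c-2cc1` differs from compound 1 by hydrogen in place of methyl on an oxygen next to a carbonyl group. Among the compounds with values here, no measured step touches the oxygen next to the carbonyl group, so the one step in hand, from trifluoromethyl in place of hydrogen, does not bear on this change. Within the data shown here, it shows only that a small change can move the read-out far in this set.

Among the measured compounds shown here, with no direct precedent, the step from the ester of compound 1 to the acid of compound 3 is estimated as a number 18.9 percentage points lower from compound 1 to compound 3 (beyond the scatter), with a wide range. In this assay compound 3 is therefore expected to give about 10%, between -45% and 50%.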

Compound 3, a percentage reported as inhibition, at one concentration (the size of the read-out at that concentration, not a potency): 32.9%
For compound 3 the middle estimate is 22.9 percentage points below the measured one; low and high end bracket the measured number.
By their numbers in this assay, from the lowest: compound 2; then compounds 1 and 3 (each within the scatter of the next).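

In this assay, hydrogen in place of methyl on an oxygen next to a carbonyl group gives a number 4 percentage points higher from compound 1 to compound 3 (within the scatter), so methoxycarbonyl and carboxy cannot be told apart on this read-out with the rest of the core of compound 1 unchanged. Within the data shown here, this change therefore contrasts with the only other step in the set, a number 76.3 percentage points lower from compound 1 to compound 2 (beyond the scatter), which lies beyond the scatter and falls at a different place on the molecule. No measured data bear on why the ester and the acid read alike.

From the compounds shown here alone, it remains open whether carboxy would read the same alongside the trifluoromethyl group of compound 2. Also open, going by these compounds, is how an ethyl ester or a primary amide would read at this place, and whether potency would follow these single-concentration numbers.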